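Replacing a chlorophenyl with a dimethyl-oxazole on the aryl core

This account rests on a few compounds, and the source may have more. Where it says the series, first, only, none or still open, it means among the compounds named here.

Of the compounds shown here, two have been tested in a functional assay on CHO cells for agonist activity at Free fatty acid receptor 1 (Homo sapiens), read by FLIPR and calcium flux; on this read-out higher numbers stand for an effect only at larger amounts of compound and lower numbers for an effect already at smaller amounts. Within the data shown here, compound 1, `O=C(O)CS(=O)(=O)c1ccc(OCc2cccc(-c3ccccc3Cl)c2)cc1`, carries a 2-chlorophenyl group on its aromatic core and is the only compound here with a full number: in this assay compound 1 gives 28.8 nM. Compound 2, `COc1cc(C)c(-c2cccc(COc3ccc(S(=O)(=O)C4(C(=O)O)CC4)cc3)c2)c(C)c1`, differs in several places at once and gives only a limit in this assay, > 1000 nM, which states that no effect was seen within the tested range; this is the limit of > 1000 nM in this assay, at which 1 of the 2 values shown sits. Compound 3, `Cc1noc(C)c1-c1cccc(COc2ccc(S(=O)(=O)CC(=O)O)cc2)c1`, has not yet been measured and differs from compound 1 in a single place: 3,5-dimethyl-1,2-oxazol-4-yl in place of 2-chlorophenyl on an aromatic carbon. Among the measured compounds shown here, no measured pair shows this exact change, so its size is uncertain. Compound 3 is estimated at 60 nM in this assay, between 15 nM and 300 nM, a step of a 2.1-fold higher number from compound 1 to compound 3 (0.32 log units; beyond the scatter) that could well sit within the scatter.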

Compound 3, half-maximal effective concentration: 269 nM
Estimate against measurement, compound 3: 4.5-fold (0.65 log units) below; low and high end bracket the measured number.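

In this assay, among these compounds, placing 3,5-dimethyl-1,2-oxazol-4-yl instead of 2-chlorophenyl on this aromatic carbon, meta to a large group, comes with a 9.3-fold higher number from compound 1 to compound 3 (0.97 log units; beyond the scatter) and is the first single change read at this position. This position therefore does not treat the two groups alike, even though they have the same count of heavy atoms and neither carries a net charge. Compound 3 still gives a full number rather than a limit, so a five-membered aromatic ring with 2 hetero atoms can sit here, although at a clear cost in this read-out.

No measurement shown explains the size of this step. Going by these compounds, it remains open whether a plain phenyl or a pyridine ring here would stay closer to compound 1 or to compound 3.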